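This account rests on a few compounds, and the source may have more. Where it says the series, first, only, none or still open, it means among the compounds named here.

Measured compounds:
- compound 1, `COc1cc(-c2cc(/C=C/C(=O)c3ccc(N)cc3)[nH]n2)cc(OC)c1OC`, 8320 nM
- compound 2, `COc1ccc(C(=O)/C=C/c2cc(-c3cc(OC)c(OC)c(OC)c3)n[nH]2)cc1OC`, 7820 nM

Both were tested in a functional assay on SK-OV-3 cells (Homo sapiens) for inhibition, read by sulforhodamine B assay, with a stated time of 48 h (a higher number here means a weaker inhibitor of growth, a lower number a stronger inhibitor of growth), where compound 1 gives 8320 nM and compound 2 gives 7820 nM. Compound 2 thus stands alongside compound 1, the two numbers lying within the scatter of each other, as the step of a 1.1-fold lower number from compound 1 to compound 2 (0.03 log units; within the scatter) shows.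

The next compound, compound 3, `COc1cc(-c2cc(/C=C/C(=O)c3ccc(F)c(F)c3)[nH]n2)cc(OC)c1OC`, differs from compound 2 at one place: 3,4-difluorophenyl in place of 3,4-dimethoxyphenyl on a carbonyl carbon

Among the measured compounds shown here, the only measured step that bears on this change is the one on the same carbonyl carbon, a 1.1-fold lower number from compound 1 to compound 2 (0.03 log units; within the scatter). There the group on that carbon was swapped and the number did not move beyond the scatter. For the measured compounds named here, no step involving a difluorophenyl group has been measured. Taking the one step as a guide, compound 3 is expected to give a number near that of compound 2, with the step of a 1.0-fold higher number from compound 2 to compound 3 (0.01 log units; within the scatter) expected to stay within the scatter. Compound 3 is therefore estimated at 8000 nM, with a range from 3000 nM to 22000 nM.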

Compound 3, concentration for total growth inhibition: 58600 nM
Beside the measured number, compound 3's estimate is 7.3-fold (0.86 log units) below it; the whole stated range lies below it.
By their numbers in this assay, from the lowest: compounds 2 and 1 (each within the scatter of the next); then compound 3.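

In this assay, the group on the carbonyl carbon proves not to be a free choice: putting 3,4-difluorophenyl there in place of 3,4-dimethoxyphenyl gives a 7.5-fold higher number from compound 2 to compound 3 (0.87 log units; beyond the scatter), and putting it there in place of 4-aminophenyl gives a 7.0-fold higher number from compound 1 to compound 3 (0.85 log units; beyond the scatter). The earlier result, in which two different groups at this place stayed within the scatter of each other, therefore does not hold for every aromatic ring, and compound 3 is the weakest inhibitor of growth of the three. The leaving and entering groups each hold one six-membered aromatic ring of carbon only, so the loss goes with what is attached to that ring, but no measurement here gives a reason for it.

The compounds shown leave open whether both fluorines are needed for this loss, or whether it would also appear with a single fluorine, as in 4-fluorophenyl, or with a plain phenyl ring carrying no further groups. They also leave open whether a group such as 4-hydroxyphenyl or 3,4-dichlorophenyl would stay close to compound 2 or fall away like compound 3.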